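Sulfoxide to Sulfone on a Longer Chain

The source may hold more compounds than are shown below. What is called first, only, known or untested is meant among the compounds shown, and "the series" means these compounds.

Of the compounds shown here, three sharing one core have been tested in a functional assay on the whole organism with Rattus norvegicus as the target; a lower number here means that less compound is needed, a higher number that more compound is needed for the effect. Compound 1 `C[S+]([O-])CCn1c(=N)sc2cc(OC(F)(F)F)ccc21` gives 1.1 mg/kg in this assay. Compound 2 `CS(=O)(=O)CCn1c(=N)sc2cc(OC(F)(F)F)ccc21` differs from it by a group of 4 heavy atoms (1 carbon, 2 oxygen, 1 sulfur; no ring) in place of a group of 3 heavy atoms (1 carbon, 1 oxygen, 1 sulfur; no ring), on a saturated chain carbon, two bonds along the chain from an aromatic nitrogen, and in this assay compound 2 gives 1.8 mg/kg, so that a 1.6-fold higher number from compound 1 to compound 2 (0.21 log units; within the scatter). Compound 3 `C[S+]([O-])CCCn1c(=N)sc2cc(OC(F)(F)F)ccc21` differs from compound 1 by a group of 4 heavy atoms (2 carbon, 1 oxygen, 1 sulfur; no ring) in place of a group of 3 heavy atoms (1 carbon, 1 oxygen, 1 sulfur; no ring), on a saturated chain carbon, two bonds along the chain from an aromatic nitrogen, and in this assay compound 3 gives 2.3 mg/kg, a change of a 2.1-fold higher number from compound 1 to compound 3 (0.32 log units; beyond the scatter). Between compound 2 and compound 3 the data show a 1.3-fold higher number from compound 2 to compound 3 (0.11 log units; within the scatter).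

Compound 4 `CS(=O)(=O)CCCn1c(=N)sc2cc(OC(F)(F)F)ccc21` has not yet been measured in this assay. It differs from compound 3 by a group of 4 heavy atoms (1 carbon, 2 oxygen, 1 sulfur; no ring) in place of a group of 3 heavy atoms (1 carbon, 1 oxygen, 1 sulfur; no ring), on a saturated chain carbon, three bonds along the chain from an aromatic nitrogen. Going by the values given here, this is the same kind of change as the one from compound 1 to compound 2, but the place is not identical: there the group sits two bonds along the chain from an aromatic nitrogen, here three bonds along the chain from an aromatic nitrogen. The cores of compound 3 and compound 4 differ from those of compound 1 and compound 2 in the way given under the difference from compound 1 to compound 3.

Resting on the step from compound 1 to compound 2 given above, compound 4 is expected to show a step of about a 1.6-fold higher number from compound 3 to compound 4 (0.21 log units; within the scatter) from compound 3. The value estimated for compound 4 in this assay is therefore 3.7 mg/kg, with an expected range from 2 mg/kg to 7 mg/kg.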

Compound 4, dose for half-maximal effect: 5 mg/kg
For compound 4 the middle estimate is 1.4-fold (0.13 log units) below the measured one; measured number inside the range.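

In this assay, methylsulfonyl on the longer chain gives a 2.2-fold higher number from compound 3 to compound 4 (0.34 log units; beyond the scatter), lengthening the chain with methylsulfonyl in place gives a 2.8-fold higher number from compound 2 to compound 4 (0.44 log units; beyond the scatter), and the two changes together give a 4.5-fold higher number from compound 1 to compound 4 (0.66 log units; beyond the scatter). On these two cores the change goes the same way, and the size of the step cannot be told apart between them: the same change on two cores in this assay, a 1.6-fold higher number (0.21 log units; within the scatter) from compound 1 to compound 2 and a 2.2-fold higher number (0.34 log units; beyond the scatter) from compound 3 to compound 4, 1.3-fold (0.12 log units) apart, within the scatter of two such steps. Going by these compounds alone, this is only a single pair of steps, one of which lies within the scatter on its own, so it shows that carrying the change from the shorter chain to the longer one is consistent with these data, not that the step has a fixed size or that it would hold on any other core.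

The compounds shown leave open whether the same steps would appear on a longer chain still, or with a thioether or a carboxylic acid in place of the sulfur groups. They also leave open whether the pair would behave alike if chlorine stood in place of the trifluoromethoxy group on the shared core.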